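The compounds below may be only part of what the source reports. "The series", "measured", "known", "first", "only" and "open" are said of these compounds alone.

Three compounds carry a shared core that ends in a basic dimethylamino chain. Compound 1 `CN(C)CCCC(=O)Nc1ccc(CN2N=C(c3ccc(F)cc3)C3C=CC=CC3C2=O)cc1` gives 38200 nM in an ADME assay on Huh-7 cells (Homo sapiens) for cytotoxicity, read by MTT assay, with a stated time of 48 h; a higher number here means that more compound is tolerated, a lower number that less compound is tolerated. Compound 2 `CN(C)CCCCNC(=O)Nc1ccc(CN2N=C(c3ccc(F)cc3)C3C=CC=CC3C2=O)cc1` gives 46600 nM in this assay, a move described as a 1.2-fold higher number from compound 1 to compound 2 (0.09 log units; within the scatter). Compound 3 `CN(C)CCCCOC(=O)Nc1ccc(Cn2nc(-c3cnn(C)c3)c3ccccc3c2=O)cc1` gives 55900 nM in this assay; this is the highest of the three numbers, though its gap to compound 2 and its gap to compound 1 are both within the scatter, so no order among the three can be claimed.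

The unmeasured compound 4 `CN(C)CCCCOC(=O)Nc1ccc(Cn2nc(-c3ccccc3C#N)c3ccccc3c2=O)cc1` differs from compound 3 in one place: 2-cyanophenyl in place of 1-methyl-1H-pyrazol-4-yl on an aromatic carbon. Going by the values given here, no measured step touches this part of the core; the single measured step concerns the chain at the other end, and it stayed within the scatter. The data therefore give no ground to expect a move beyond the scatter in this assay, and compound 4 is estimated at 50000 nM (range 25000 nM to 100000 nM), a step of a 1.1-fold lower number from compound 3 to compound 4 (0.05 log units; within the scatter) that is expected to be flat.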

Compound 4, half-maximal cytotoxic concentration: 90700 nM
The estimate for compound 4 lay 1.8-fold (0.26 log units) below the measured number; the measured number falls inside the stated range.
By their numbers in this assay, from the lowest: compounds 1, 2, 3 and 4 (each within the scatter of the next, the first and the last beyond it).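

In this assay, going by these compounds alone, the exchange of 1-methyl-1H-pyrazol-4-yl for 2-cyanophenyl gave a 1.6-fold higher number from compound 3 to compound 4 (0.21 log units; within the scatter), the first reading for a change at this aromatic carbon next to the ring nitrogen. Within the data shown here, the position therefore took a six-membered aromatic ring of carbon only, carrying a nitrile, in place of a five-membered aromatic ring with 2 hetero atoms, and the step stayed within the scatter, as the one step measured earlier at the chain had done. Nothing measured here speaks to why the step is this small.

On these data alone, whether an aliphatic amine or a carboxylic acid at this position would move the number beyond the scatter remains open. So does how much of this step belongs to the nitrile and how much to the phenyl ring that carries it.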